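A Hydroxy Group and Cell Tolerance in Three Amides

A few compounds are considered here, and "the series" means these few. Any claim that something is new, unique, unknown or untested is made for them only; others in the source may bear on it.

Compound 1, `O=C(Nc1cccc(Cl)c1)c1cc(Br)cc(Br)c1O`: 18000 nM
Compound 2, `O=C(Nc1cccc(Cl)c1)c1cc(Br)cc(Br)c1`: 53000 nM
Compound 3, `O=C(Nc1ccc(Sc2nc3ccccc3s2)cc1)c1cccc(Br)c1`: 74000 nM

Three amides were tested in an ADME assay on HEK293 cells (Homo sapiens) for cytotoxicity, read by reporter gene assay and resazurin assay, with a stated time of 48 h; a lower number here means that less compound is tolerated, a higher number that more compound is tolerated. Compound 1 and compound 2 share a core and differ in one place: hydroxy in place of hydrogen on an aromatic carbon. In this assay that change gave a 2.9-fold lower number from compound 2 to compound 1 (0.47 log units; beyond the scatter). Compound 3 carries a different core; the difference between the core of compound 3 and the core of compound 2 is not broken down here. The numbers of compound 2 and compound 3 lie within the scatter of each other, while the number of compound 1 lies beyond the scatter from that of compound 3.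

Compound 4, `O=C(Nc1ccc(Sc2nc3ccccc3s2)cc1)c1cc(Br)ccc1O`, has not yet been measured. It differs from compound 3 by the change (hydroxy in place of hydrogen on an aromatic carbon). Going by the values given here, this is the same kind of change as the one from compound 2 to compound 1, but not the same: in compound 1 the entering hydroxy is also ortho to a bromo group, whereas in compound 4 it is ortho to a large group and para to a bromo group only.

Because the earlier change gave a 2.9-fold lower number from compound 2 to compound 1 (0.47 log units; beyond the scatter), a step of similar size is expected here, and for compound 4 in this assay the expected step is a 2.6-fold lower number from compound 3 to compound 4 (0.42 log units; beyond the scatter). The estimate for compound 4 is therefore 28000 nM, within a range from 12000 nM to 70000 nM.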

Compound 4, half-maximal cytotoxic concentration: 42000 nM
The estimate for compound 4 lay 1.5-fold (0.18 log units) below the measured number, and the stated range covers the measured number.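

Placed on the core of compound 3, hydroxy in place of hydrogen on an aromatic carbon gave a 1.8-fold lower number from compound 3 to compound 4 (0.25 log units; within the scatter), so on this core alone the numbers of the two compounds in this assay cannot be told apart. Set beside the earlier step on the other core, the change shows no measurable dependence on the core: the same change on two cores in this assay, a 2.9-fold lower number (0.47 log units; beyond the scatter) from compound 2 to compound 1 and a 1.8-fold lower number (0.25 log units; within the scatter) from compound 3 to compound 4, 1.7-fold (0.22 log units) apart, within the scatter of two such steps This agrees with a step that carries over between these two cores, but it does not prove that it does, since the evidence is only two pairs, one of whose steps lies within the scatter, and the change from 3-bromophenyl to 5-bromo-2-hydroxyphenyl places the hydroxy differently from the change in compound 1, so any effect of core cannot be separated from one of placement.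

The compounds shown leave open whether the same step would appear on further cores, or with the hydroxy at another carbon of the same ring. They also leave open how a methoxy group, an amine or a carboxylic acid at the same aromatic carbon would compare with the hydroxy in this assay.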